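This account rests on a few compounds, and the source may have more. Where it says the series, first, only, none or still open, it means among the compounds named here.

Measured compounds in the series:

- Compound 1, `Cc1cnc(Nc2ccc(C#N)cc2)nc1Nc1c(F)cc(-c2cccs2)cc1F`: 8000 nM
- Compound 2, `Cc1cnc(Nc2ccc(C#N)cc2)nc1Nc1c(F)cc(-c2cncc(C(F)(F)F)c2)cc1F`: 8200 nM
- Compound 3, `Cc1cc(-c2ccco2)cc(C)c1Nc1ccnc(Nc2ccc(C#N)cc2)n1`: 1700 nM

All three numbers come from a toxicity assay on MT4 cells (Homo sapiens) for cytotoxicity, read by MTT assay, with a stated time of 5 days; a higher number here means that more compound is tolerated, a lower number that less compound is tolerated. Compound 3 gives the lowest number of the three, with compound 1 the nearest and compound 2 the furthest, both beyond the scatter; compounds 1 and 2 are within the scatter of each other, and the step of a 1.0-fold higher number from compound 1 to compound 2 (0.01 log units; within the scatter) records that.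

Compound 4, `Cc1cc(-c2ccnc(C(F)(F)F)c2)cc(C)c1Nc1ccnc(Nc2ccc(C#N)cc2)n1`, has not been measured. It differs from compound 3 by 2-(trifluoromethyl)pyridin-4-yl in place of furan-2-yl on an aromatic carbon. Within the data shown here, the only measured step that resembles this change is the one from compound 1 to compound 2, which also exchanges a five-membered aromatic ring for a trifluoromethyl-bearing pyridine on the same kind of aromatic carbon, and it left this assay unchanged beyond the scatter. On that basis the step from compound 3 to compound 4 is expected to be a 1.2-fold higher number from compound 3 to compound 4 (0.07 log units; within the scatter), that is no change beyond the scatter. For compound 4 the estimated value in this assay is 2000 nM, with a range from 700 nM to 6000 nM.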

Compound 4, half-maximal cytotoxic concentration: 6100 nM
Estimate against measurement, compound 4: 3.1-fold (0.48 log units) below; the measured number lies above the stated range.
By their numbers in this assay, from the lowest: compound 3; then compounds 4, 1 and 2 (each within the scatter of the next).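

On the core of compound 3, the aromatic carbon meta to two methyl groups proves sensitive to its substituent in this assay, with a 3.6-fold higher number from compound 3 to compound 4 (0.55 log units; beyond the scatter) as the recorded step. The exchange of a five-membered aromatic ring for a trifluoromethyl-substituted pyridine is therefore not neutral in every setting, although a 1.0-fold higher number from compound 1 to compound 2 (0.01 log units; within the scatter) stayed flat on a different core with a different ring pair. No available data account for the rise at this position.

The compounds shown leave open whether the rise tracks the departure of furan-2-yl or the arrival of 2-(trifluoromethyl)pyridin-4-yl. They also leave open how this assay responds at this carbon to a non-aromatic substituent such as an amine or a carboxylic acid.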